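The source may report more compounds than this note shows. Statements on the series, on what has been measured and on what is new or still open speak of the compounds shown alone.

Series notes. In a functional assay for agonist activity at G protein-coupled receptor 88 (Homo sapiens), read by HTRF and cAMP accumulation (on this read-out higher numbers stand for an effect only at larger amounts of compound and lower numbers for an effect already at smaller amounts), compound 1 `CC[C@H](C)[C@H](N)CN(C(=O)[C@@H]1C[C@H]1c1ccc(F)cc1F)c1ccc(-c2ccccc2)cc1` gives 1300 nM. In this assay, among the measured compounds shown here, compound 2 `CC[C@H](C)[C@H](N)CN(C(=O)[C@@H]1C[C@H]1c1ncccn1)c1ccc(-c2ccccc2)cc1` gives 130 nM, the lowest of the two numbers so far; the single measured step, a 10-fold lower number from compound 1 to compound 2 (1.00 log units; beyond the scatter), sets compound 2 apart from compound 1 clearly. Compound 3 `CC[C@H](C)[C@H](N)CN(C(=O)[C@@H]1C[C@H]1c1nccs1)c1ccc(-c2ccccc2)cc1` is not yet measured. The change from compound 2 is 1,3-thiazol-2-yl in place of pyrimidin-2-yl on a saturated ring carbon. For the measured compounds named here, no measured step covers this exact exchange; the one step available, from 2,4-difluorophenyl to pyrimidin-2-yl, shows only that the group on the saturated ring carbon of the three-membered ring can move the number substantially. Here both the leaving and the entering group are aromatic rings with two hetero atoms and two hydrogen-bond acceptors, so the exchange is smaller than the one measured, and a second such swing is not expected. For compound 3 the expected step is a 1.9-fold higher number from compound 2 to compound 3 (0.28 log units; within the scatter), a move of modest size at most, with no firmly predicted direction. Compound 3 is therefore estimated at 250 nM, with a range from 80 nM to 800 nM.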

Compound 3, half-maximal effective concentration: 210 nM
Compound 3: middle estimate off by 1.2-fold (0.08 log units), on the high side, within the range that was stated.
By their numbers in this assay, from the lowest: compounds 2 and 3 (each within the scatter of the next); then compound 1.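

In this assay, 1,3-thiazol-2-yl in place of pyrimidin-2-yl on a saturated ring carbon of the three-membered ring gives a 1.6-fold higher number from compound 2 to compound 3 (0.21 log units; within the scatter), so a five-membered aromatic ring with sulfur and nitrogen cannot be told apart on this read-out from a six-membered aromatic ring with two nitrogens. Measured against 2,4-difluorophenyl, the 1,3-thiazol-2-yl group gives a 6.2-fold lower number from compound 1 to compound 3 (0.79 log units; beyond the scatter), so the separation from compound 1 no longer rests on pyrimidin-2-yl alone: both groups with two hetero atoms in the ring stand beyond the scatter from the 2,4-difluorophenyl group, with no exception among these three compounds. Nothing available accounts for these numbers at this position.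

Open, on these data alone, is whether a single ring nitrogen is enough: a pyridin-2-yl or an unsubstituted phenyl at this saturated ring carbon could fall with compound 2 and compound 3 or with compound 1. Also open, as far as these compounds go, is how much room the 1,3-thiazol-2-yl group leaves for substitution, for instance a methyl or an amine on that ring, with the rest of the shared core unchanged.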